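This account rests on a few compounds, and the source may have more. Where it says the series, first, only, none or still open, it means among the compounds named here.

Compound 1 `COC(=O)/C=C/c1ccncc1-c1ccc2ccccc2c1` is the reference point of this small set. In an assay on a protein complex for inhibition of CDK8/Cyclin C (Homo sapiens), with a stated time of 1 h, tested at 10 uM (on this read-out lower numbers stand for less inhibition and higher numbers for more inhibition at the one concentration tested (going by the name of the read-out)), compound 1 gives 102%, the highest of the three numbers measured. The two comparators replace its whole side chain: compound 2 `CNC(=O)COc1ccncc1-c1ccc2ccccc2c1` gives 4% in this assay, and compound 3 `NNC(=O)COc1ccncc1-c1ccc2ccccc2c1` gives 19%. The corresponding steps are large: a number 98 percentage points lower from compound 1 to compound 2 (beyond the scatter) and a number 83 percentage points lower from compound 1 to compound 3 (beyond the scatter), each well beyond the scatter, while the step between the two amides is smaller, a number 15 percentage points higher from compound 2 to compound 3 (beyond the scatter).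

Compound 4 `O=C(/C=C/c1ccncc1-c1ccc2ccccc2c1)N1CCOCC1` keeps the ethenyl linker of compound 1 and alters only the group on its carbonyl carbon: morpholin-4-yl in place of methoxy on a carbonyl carbon. Among the compounds with values here, none of the measured steps isolates this change; the large drops from compound 1 to compound 2 and compound 3 involve exchange of the whole ethenyl ester for an oxyacetamide, so they bear only loosely on it. Because compound 1 gives 102% and the linker is retained, compound 4 is expected to stay strongly inhibiting, with a modest expected step of a number 17 percentage points lower from compound 1 to compound 4 (beyond the scatter). The estimate for compound 4 is 85%, within a range of 50% to 105%.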

Compound 4, a percentage reported as inhibition, at one concentration (the size of the read-out at that concentration, not a potency): 99%
Compound 4: the middle estimate sits 14 percentage points below what was measured, and the stated range covers the measured number.
By their numbers in this assay, from the lowest: compound 2; then compound 3; then compounds 4 and 1 (each within the scatter of the next).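

On the carbonyl carbon of the ethenyl side chain, morpholin-4-yl in place of methoxy gives a number 3 percentage points lower from compound 1 to compound 4 (within the scatter), so in this assay the two compounds cannot be told apart. The earlier compounds shown here showed only what happens when the whole side chain is exchanged, whereas this pair shows that the methoxy of the ester can give way to a six-membered ring of six heavy atoms, with the ethenyl linker kept, and the read-out stays within the scatter. Nothing measured here offers an explanation for this result.

From the compounds shown here alone, whether a carboxylic acid, an open-chain dimethylamide or a saturated ethyl linker would read the same at this part of the side chain stays open. Going by these compounds, the single concentration gives no potency, so any difference in potency between compound 1 and compound 4 also stays open.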